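Bromo for methyl beside a phenol in an imidazole-thione series

The source may hold more compounds than are shown below. What is called first, only, known or untested is meant among the compounds shown, and "the series" means these compounds.

Of the compounds shown here, two have been measured in an assay on isolated protein for inhibition of Dopamine beta-hydroxylase (Rattus norvegicus); on this read-out lower numbers stand for stronger inhibition and higher numbers for weaker inhibition. Compound 1 `Cc1cc(Cn2cc[nH]c2=S)ccc1O` gives 49000 nM, and compound 2 `S=c1[nH]ccn1Cc1ccc(Br)cc1` gives 115000 nM. Compound 1 therefore holds the lowest of the two numbers, with compound 2 coming in higher by a margin that lies beyond the usual scatter of the assay.

Compound 3 `Oc1ccc(Cn2cc[nH]c2=S)cc1Br` is not yet measured. It differs from compound 1 in a single place: bromo in place of methyl on an aromatic carbon, which is to say bromo in place of methyl on an aromatic carbon, ortho to a hydroxy group. Going by the values given here, no pair of measured compounds shows the effect of this exchange, so any expectation rests on the position of compound 1 alone. Compound 3 is expected to land somewhat lower than compound 1, by a 2.0-fold lower number from compound 1 to compound 3 (0.29 log units; within the scatter), a step that could well be within the scatter. The estimate for compound 3 in this assay is 25000 nM, with a range from 8000 nM to 80000 nM.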

Compound 3, half-maximal inhibitory concentration: 12000 nM
Beside the measured number, compound 3's estimate is 2.1-fold (0.32 log units) above it, within the range that was stated.
By their numbers in this assay, from the lowest: compound 3; then compound 1; then compound 2.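

In this assay, bromo in place of methyl on this aromatic carbon, ortho to a hydroxy group, gives a 4.1-fold lower number from compound 1 to compound 3 (0.61 log units; beyond the scatter) and so moves the read-out by more than the usual variation between repeats. Going by these compounds alone, compound 1 and compound 2 alone offered no step at this position, so this pair is the first to show that the group placed here matters for inhibition of the enzyme. Nothing available bears on why the number falls, and the result stands as an observation on this one exchange.

Going by these compounds, whether chloro, iodo, methoxy or an amine at the same place would match or pass bromo remains open. So does whether the step would persist if the hydroxy group were replaced by a methoxy group or a carboxylic acid.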